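This account rests on a few compounds, and the source may have more. Where it says the series, first, only, none or still open, it means among the compounds named here.

Going by the values given here, compound 3 (`CN(C)c1ccc(/C=C/c2cc(=O)c(O)cn2C)cc1`) stands close to compound 1 (`O=c1cc(/C=C/c2ccc(O)cc2)[nH]cc1O`) in a functional assay, with a stated time of 10 min (on this read-out lower numbers stand for stronger inhibition and higher numbers for weaker inhibition), on the numbers so far. Compound 3 gives 2520 nM and compound 1 gives 1730 nM and these two values lie within the scatter of each other. Compound 2 (`Cn1cc(O)c(=O)cc1/C=C/c1ccc(Cl)cc1`) gives 5720 nM as the highest number of the three.

Compound 4 (`Cn1cc(O)c(=O)cc1/C=C/c1ccc(O)cc1`) follows from compound 3 with hydroxy in place of dimethylamino on an aromatic carbon. Among the compounds with values here, the one measured step at this place, dimethylamino in place of chloro on an aromatic carbon, is modest but beyond the scatter (a 2.3-fold lower number from compound 2 to compound 3 (0.36 log units; beyond the scatter)). Compound 1 also carries hydroxy at this place, and its 1730 nM lies within the scatter of compound 3. Only a small move is therefore expected in this assay, if anything toward a lower number. The expected step is a 1.3-fold lower number from compound 3 to compound 4 (0.10 log units; within the scatter) and it should stay within the scatter. Compound 4 is expected at 2000 nM (estimated range 900 nM to 4500 nM).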

Compound 4, half-maximal inhibitory concentration: 1370 nM
The estimate for compound 4 lay 1.5-fold (0.16 log units) above the measured number; the range from low to high includes it.
By their numbers in this assay, from the lowest: compounds 4, 1 and 3 (each within the scatter of the next); then compound 2.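

At this place on the aromatic carbon, hydroxy and dimethylamino cannot be told apart in this assay (a 1.8-fold lower number from compound 3 to compound 4 (0.26 log units; within the scatter)), whereas hydroxy in place of chloro gives a step beyond the scatter (a 4.2-fold lower number from compound 2 to compound 4 (0.62 log units; beyond the scatter)), so among the three groups tried here, only chloro stands apart. The new compound also gives the first single-place view of the aromatic nitrogen, where methyl in place of hydrogen stays within the scatter (a 1.3-fold lower number from compound 1 to compound 4 (0.10 log units; within the scatter)). Nothing on hand gives a reason for these results.

The compounds shown leave open whether methoxy, an amine such as amino, or a carboxylic acid at this place would group with hydroxy or with chloro. They also leave open whether a longer chain on the aromatic nitrogen, such as ethyl, would stay as close as methyl does.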